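Cyclopropyl amide of the acid, compound 1 to compound 4

The compounds below may be only part of what the source reports. "The series", "measured", "known", "first", "only" and "open" are said of these compounds alone.

Measured so far in a functional assay on MDA-MB-231 cells (Homo sapiens) for inhibition, read by sulforhodamine B assay, with a stated time of 72 h; a lower number here means a stronger inhibitor of growth, a higher number a weaker inhibitor of growth:
- compound 1 `O=C(O)/C=C/c1ccncc1-c1ccc2ccccc2c1`: > 10000 nM (a limit)
- compound 2 `O=C(/C=C/c1ccncc1-c1ccc2cc[nH]c2c1)N1CCOCC1`: > 10000 nM (a limit)
- compound 3 `CCOC(=O)/C=C/c1ccncc1-c1ccc2c(ccn2C)c1`: 10200 nM

For the measured compounds named here, the series so far is defined by the limit of > 10000 nM in this assay, at which 2 of the 3 values shown sit. Compound 1 stands at that limit, so its value of > 10000 nM is a limit and not a number. Compound 2, also an amide, has a value of > 10000 nM, which is likewise a limit. Going by the values given here, only compound 3 gives a number, 10200 nM, and it differs from compound 1 in more than one place, so it offers no clean step.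

Compound 4 `O=C(/C=C/c1ccncc1-c1ccc2ccccc2c1)NC1CC1` keeps the core of compound 1 and has cyclopropylamino in place of hydroxy on a carbonyl carbon, turning carboxy into cyclopropylcarbamoyl: cyclopropylamino in place of hydroxy on a carbonyl carbon.

Among the compounds with values here, with no measured step to go on, only a modest shift in this assay is expected, and compound 2 at > 10000 nM argues against expecting much from an amide. The expected step of an at least 1.1-fold lower number from compound 1 to compound 4 (0.04 log units; that floor lies within the scatter) is small, in the direction of stronger growth inhibition. For compound 4 the estimated value is 9000 nM, with an expected range of 3000 nM to 25000 nM.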

Compound 4, concentration for 50% growth inhibition: 8420 nM
Compound 4: middle estimate off by 1.1-fold (0.03 log units), on the high side, within the range that was stated.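

Compound 1 stands in this assay at > 10000 nM, which is a limit and not a number. Cyclopropylamino in place of hydroxy on a carbonyl carbon gives the first readable step in the series, an at least 1.1-fold lower number from compound 1 to compound 4 (0.07 log units; that floor lies within the scatter), and compound 4 gives a measured number where compound 1 gives none. Only a floor for this change can be stated, and its true size stays unknown, because compound 1 stands at the limit of the assay: the limit of > 10000 nM in this assay, at which 2 of the 4 values shown sit.

On these data alone, whether other groups on this carbonyl carbon, such as methylamino, dimethylamino or a longer alkyl chain on the amide nitrogen, would shift the number in this assay remains open. Also open, as far as these compounds go, is whether cyclopropylamino would give a similar result on the other cores of the series, since compound 2 and compound 3 each differ from compound 4 in more than one place and offer no clean comparison.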